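The source may hold more compounds than are shown below. What is called first, only, known or untested is meant among the compounds shown, and "the series" means these compounds.

Measured in a functional assay on the whole organism (strain Swiss albino) with Mus musculus as the target, in the maximal electroshock model, with a stated time of 2 h; on this read-out higher numbers stand for an effect only at larger amounts of compound and lower numbers for an effect already at smaller amounts:
- compound 1 `O=C1C(c2ccccc2Cl)CC(c2ccccc2Cl)C(=O)N1c1cccc(Cl)c1`; compound 1 gives 60.2 mg/kg
- compound 2 `Cc1ccccc1N1C(=O)C(c2ccccc2Cl)CC(c2ccccc2Cl)C1=O`; compound 2 gives 27.4 mg/kg

Compound 2 holds the lower of the two numbers; the step of a 2.2-fold lower number from compound 1 to compound 2 (0.34 log units; beyond the scatter) lies beyond the scatter. Compound 3 `Cc1ccc(N2C(=O)C(c3ccccc3Cl)CC(c3ccccc3Cl)C2=O)cc1` differs from compound 2 in one place: 4-methylphenyl in place of 2-methylphenyl on an amide-type nitrogen in a ring. For the measured compounds named here, no measured step bears directly on this change, since a 2.2-fold lower number from compound 1 to compound 2 (0.34 log units; beyond the scatter) exchanges the whole aryl group rather than the position of the methyl, and it gives no guide to direction. No step beyond the scatter is therefore expected. Compound 3 is estimated at 35 mg/kg, between 15 mg/kg and 80 mg/kg, which means an expected step of a 1.3-fold higher number from compound 2 to compound 3 (0.11 log units; within the scatter).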

Compound 3, dose for half-maximal effect: 41.2 mg/kg
Compound 3: middle estimate off by 1.2-fold (0.07 log units), on the low side, within the range that was stated.
By their numbers in this assay, from the lowest: compounds 2, 3 and 1 (each within the scatter of the next, the first and the last beyond it).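

Exchanging 2-methylphenyl for 4-methylphenyl on the amide-type nitrogen gives a 1.5-fold higher number from compound 2 to compound 3 (0.18 log units; within the scatter), so these two methylphenyl groups are not told apart on this read-out. Exchanging 3-chlorophenyl for 4-methylphenyl gives a 1.5-fold lower number from compound 1 to compound 3 (0.16 log units; within the scatter), so compound 3 lies within the scatter of both neighbours, and only compounds 1 and 2 stand apart. No measurement available accounts for these steps. Open, going by these compounds, is whether a methoxy or dimethylamino group on this phenyl ring, or a longer alkyl chain in place of the aryl group on the nitrogen, would leave the number within this span.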